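A few compounds are considered here, and "the series" means these few. Any claim that something is new, unique, unknown or untested is made for them only; others in the source may bear on it.

Measured so far in a functional assay on MCF7 cells (Homo sapiens) for antiproliferative activity, read by MTT assay, with a stated time of 72 h; on this read-out lower numbers stand for stronger inhibition and higher numbers for weaker inhibition:
- Compound 1 `COc1cc(-c2ncnn2-c2cccc(F)c2)cc(OC)c1OC`: > 10000 nM (a limit)
- Compound 2 `COc1cc(-c2ncnn2-c2ccccc2)cc(OC)c1OC`: > 10000 nM (a limit)

Compound 2 has no actual number on this scale, only the limit > 10000 nM. The one other result, for compound 1, is also a limit, so the limit of > 10000 nM in this assay, at which 2 of the 2 values shown sit, describes everything measured so far.

Compound 3 `COc1ccc(-n2ncnc2-c2cc(OC)c(OC)c(OC)c2)cc1` differs from compound 2 by methoxy in place of hydrogen on an aromatic carbon, para to a large group, which turns phenyl into 4-methoxyphenyl: methoxy in place of hydrogen on an aromatic carbon.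

For the measured compounds named here, the only measured step that bears on this change is also a swap of one small group on an aromatic carbon: a step that the two limits leave unreadable from compound 1 to compound 2. It has no readable size, so it offers no size to carry over, and it gives only weak guidance on direction. A result for compound 3 can differ readably from the limit of this assay only on the side of stronger inhibition, although compound 3 may well stay at that limit.

The expected change is an at least 5.0-fold lower number from compound 2 to compound 3 (0.69 log units; beyond the scatter). For compound 3 the estimate is 2000 nM, with an expected range from 100 nM to 20000 nM.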

Compound 3, half-maximal inhibitory concentration: 7400 nM
Beside the measured number, compound 3's estimate is 3.7-fold (0.57 log units) below it, and the stated range covers the measured number.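

Methoxy on an aromatic carbon, para to a large group, gives the first actual number in this assay, with compound 3 at 7400 nM on this scale. Compound 1 and compound 2 each gave only a limit, so neither offered a number to set it against: the limit of > 10000 nM in this assay, at which 2 of the 3 values shown sit. Going by these compounds, the change from phenyl to 4-methoxyphenyl therefore brings the read-out off that limit, but the steps can be stated only as floors, namely an at least 1.3-fold lower number from compound 2 to compound 3 (0.13 log units; that floor lies within the scatter) and an at least 1.3-fold lower number from compound 1 to compound 3 (0.13 log units; that floor lies within the scatter), and neither floor by itself shows a difference beyond the usual scatter, so the true size of each step remains unknown.

Still open, on these data alone, is whether this result is specific to methoxy, or whether a hydroxy group, an amine or a longer ether such as ethoxy at the same place would also give a measurable number on the shared core. The three compounds also leave open how far the antiproliferative effect can be pushed, since a single measured number marks one point and does not yet describe a trend.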